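This account rests on a few compounds, and the source may have more. Where it says the series, first, only, none or still open, it means among the compounds named here.

In an assay on isolated protein for inhibition of Gonadotropin-releasing hormone receptor (Rattus norvegicus) (a lower number here means a stronger inhibitor, a higher number a weaker inhibitor), three compounds of a shared core have been measured. Compound 1 `CCCn1c(SCc2cc([N+](=O)[O-])ccc2OC)nc2cc(NC(=O)NC(C)(C)C)ccc21` gives 120 nM, and compound 2 `COc1ccc([N+](=O)[O-])cc1CSc1nc2cc(NC(=O)NC(C)(C)C)ccc2n1Cc1cccnc1` gives 150 nM; the single-change step between them, a 1.3-fold higher number from compound 1 to compound 2 (0.10 log units; within the scatter), lies within the scatter. Going by the values given here, compound 3 `COc1ccc([N+](=O)[O-])cc1CSc1nc2cc(NC(=O)OC(C)(C)C)ccc2n1C(C)C` gives 710 nM, the highest number of the three, beyond the scatter from both compound 2 and compound 1, though it differs from each of them in two places, so no single-change step reaches it.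

Compound 4 `COc1ccc([N+](=O)[O-])cc1CSc1nc2cc(NC(=O)NC3CC3)ccc2n1C(C)C` differs from compound 3 in one place: cyclopropylamino in place of tert-butoxy on a carbonyl carbon. Among the compounds with values here, no measured step isolates this change. What the values show is that compound 1 and compound 2, which carry a carbamoyl-type group at this position, sit well below compound 3, which carries the tert-butoxycarbonyl group, while their nitrogen substituent differs as well. On that basis a lower number is expected for compound 4 in this assay, of moderate size, with wide uncertainty because the evidence comes from compound 3 at 710 nM set against compounds that are not single-change neighbours. The expected step is a 2.8-fold lower number from compound 3 to compound 4 (0.45 log units; beyond the scatter). Compound 4 is therefore estimated at 250 nM, within a range of 70 nM to 900 nM.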

Compound 4, half-maximal inhibitory concentration: 1600 nM
Compound 4: middle estimate off by 6.4-fold (0.81 log units), on the low side; measured number outside the range, above it.
By their numbers in this assay, from the lowest: compounds 1 and 2 (each within the scatter of the next); then compound 3; then compound 4.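

In this assay, going by these compounds alone, the change from tert-butoxy to cyclopropylamino, on a carbonyl carbon whose other neighbour is an amide-type nitrogen, gives a 2.3-fold higher number from compound 3 to compound 4 (0.35 log units; beyond the scatter) and so provides the first single-change reading at this place, one that runs towards a weaker inhibitor. A cyclopropylcarbamoyl group therefore does not by itself bring a lower number on the background of compound 3, and the lower numbers of compound 1 and compound 2 cannot be credited to a carbamoyl-type group alone. The change removes an open group joined through oxygen and brings in a three-membered ring joined through nitrogen, with one hydrogen-bond donor, and no evidence here bears on which of these differences matters.

The compounds shown leave open whether the rise follows the linking atom or the group carried on it, a question that cyclopropoxy or tert-butylamino on the same carbonyl carbon of compound 3 would address. They also leave open how far the effect of this change depends on the substituent on the ring nitrogen, and how dimethylamino or a longer chain such as n-butylamino would read at this place.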